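Compound 3 to compound 4: a solubility estimate

The compounds below may be only part of what the source reports. "The series", "measured", "known", "first", "only" and "open" are said of these compounds alone.

Measured so far in a physicochemical assay for solubility, in phosphate buffer, measured as thermodynamic solubility, at pH 7.4; a lower number here means a less soluble compound, a higher number a more soluble compound
- compound 1 `CS(=O)(=O)NC(=O)CCc1cn(-c2ccc(Br)cc2)nc1-c1ccncc1` gives 185000 nM
- compound 2 `CS(=O)(=O)NC(=O)CCc1cn(-c2ccc(Br)cc2)nc1C1CCOCC1` gives 200000 nM
- compound 3 `CN(C(=O)CCc1cn(-c2ccc(Br)cc2)nc1-c1ccc(Cl)cc1)S(C)(=O)=O` gives < 5000 nM as a limit

Compound 3 has no exact number, only the limit of < 5000 nM in this assay, at which 1 of the 3 values shown sits, and that is a limit. Compound 4 `O=C(CCc1cn(-c2ccc(Br)cc2)nc1-c1ccc(Cl)cc1)NS(=O)(=O)C1CC1` differs from it in one place (cyclopropylsulfonyl)amino in place of methyl(methylsulfonyl)amino on a carbonyl carbon with (cyclopropylsulfonyl)amino in place of methyl(methylsulfonyl)amino on a carbonyl carbon. Among the measured compounds shown here, no measured step covers this change. For the measured compounds named here, the one measured step, a 1.1-fold higher number from compound 1 to compound 2 (0.03 log units; within the scatter), lies within the scatter and concerns a different group, so it bears on the change only indirectly. Compound 1 and compound 2 do share the amide hydrogen that compound 4 gains, yet they also differ from compound 4 elsewhere. Their values, 185000 nM for compound 1 and 200000 nM for compound 2, therefore serve only as a loose guide. In this assay the expected size is an at least 8.0-fold higher number from compound 3 to compound 4 (0.90 log units; beyond the scatter) as a rise beyond the scatter. The estimate for compound 4 is 40000 nM with an expected range from 8000 nM to 180000 nM as its two ends.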

Compound 4, solubility: 5000 nM
Compound 4: middle estimate off by 8.0-fold (0.90 log units), on the high side; measured number outside the range, below it.
By their numbers in this assay, from the lowest: compound 4; then compounds 1 and 2 (each within the scatter of the next).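

In this assay compound 4 gives 5000 nM and so puts a real number on this core with (cyclopropylsulfonyl)amino on the carbonyl carbon. Compound 3 gives < 5000 nM and that value is a limit, not a number. The change from methyl(methylsulfonyl)amino to (cyclopropylsulfonyl)amino gives a number no lower from compound 3 to compound 4 (the limit leaves the size open), and its size therefore cannot be read, because one end of the step is only a limit: the limit of < 5000 nM in this assay, at which 1 of the 4 values shown sits.

This single step also swaps two things at once, as it gains the amide hydrogen and the three-membered ring together, so the compounds shown leave open what each does alone. From the compounds shown here alone, how a carboxylic acid or a longer chain on the sulfonyl group would read at this same place also stays open.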